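The source may report more compounds than this note shows. Statements on the series, on what has been measured and on what is new or still open speak of the compounds shown alone.

Working notes on the series. For the measured compounds named here, in an ADME assay on L02 cells (Homo sapiens) for cytotoxicity, read by MTT assay, with a stated time of 24 h (on this read-out lower numbers stand for stronger inhibition and higher numbers for weaker inhibition), compound 1 (`COc1cc(/C=C2\CN(C)C/C(=C\c3ccc(Cl)cc3)C2=O)cc(OC)c1`) gives 18900 nM and compound 2 (`COc1cc(/C=C2\CN(C)C/C(=C\c3ccc(Cl)cc3Cl)C2=O)cc(OC)c1`) gives 18800 nM, so compound 2 stands level with compound 1 on the only two numbers available. The next compound is compound 3 (`COc1cc(/C=C2\CN(C)C/C(=C\c3ccc(Cl)c(Cl)c3)C2=O)cc(OC)c1`), which has not yet been measured. The change is 3,4-dichlorophenyl in place of 2,4-dichlorophenyl on a double-bonded chain carbon bound to a double-bonded ring carbon and it places 3,4-dichlorophenyl in place of 2,4-dichlorophenyl on a double-bonded chain carbon bound to a double-bonded ring carbon. The two compounds have the same atoms, joined differently.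

Going by the values given here, one measured step bears on this, and only indirectly: chloro in place of hydrogen on an aromatic carbon (a 1.0-fold lower number from compound 1 to compound 2 (0.00 log units; within the scatter)). That step stays within the scatter. Among the compounds with values here, no measured pair shows a chlorine changing place, so the evidence is thin. On the strength of that one step, no shift beyond the scatter is expected in this assay, and no direction is favoured. The expected change is a 1.1-fold lower number from compound 2 to compound 3 (0.04 log units; within the scatter) in size. For compound 3 the estimate is 17000 nM (expected range 8500 nM to 32000 nM).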

Compound 3, half-maximal inhibitory concentration: 10600 nM
Estimate against measurement, compound 3: 1.6-fold (0.21 log units) above; the range from low to high includes it.
By their numbers in this assay, from the lowest: compounds 3, 2 and 1 (each within the scatter of the next).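

In this assay, for the compounds shown here, 3,4-dichlorophenyl in place of 2,4-dichlorophenyl on a double-bonded chain carbon bound to a double-bonded ring carbon gives a 1.8-fold lower number from compound 2 to compound 3 (0.25 log units; within the scatter) and is the first measured pair in which the two chlorines keep their number and differ only in arrangement; this step lies within the scatter. The chloro in place of hydrogen on an aromatic carbon that links the other pair gives a 1.8-fold lower number from compound 1 to compound 3 (0.25 log units; within the scatter) and also lies within the scatter, so neither of the two dichlorophenyl arrangements shown has yet moved the number beyond the scatter from that of compound 1. Nothing available accounts for these numbers or ties them to a property of either group.

The compounds shown leave open whether a group other than chloro on this phenyl ring, such as a nitrile, a carboxylic acid or a dimethylamino group, would give a step beyond the scatter in this assay at this place. Also open, from the compounds shown here alone, is whether a longer chain in place of the methyl on the nitrogen of the shared core would do so.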